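A cyano swap on compound 3

The source may report more compounds than this note shows. Statements on the series, on what has been measured and on what is new or still open speak of the compounds shown alone.

Compound 1 `CC(O)(CSc1cccc(S(F)(F)(F)(F)F)c1)C(=O)Nc1ccc(C#N)c(C(F)(F)F)c1`: 32700 nM
Compound 2 `CC(O)(CSc1cccc(OC(F)(F)F)c1)C(=O)Nc1cccc(S(F)(F)(F)(F)F)c1`: 25000 nM
Compound 3 `CC(O)(COc1ccc(S(F)(F)(F)(F)F)cc1)C(=O)Nc1ccc(S(F)(F)(F)(F)F)cc1`: 24900 nM

These values come from a functional assay on DU-145 cells (Homo sapiens) for antiproliferative activity, read by propidium iodide staining, with a stated time of 96 h; a lower number here means a stronger inhibitor, a higher number a weaker inhibitor. Compound 3 stands level with compound 1 and compound 2, with all three values within the scatter of one another. Compound 4 `CC(O)(COc1ccc(C#N)cc1)C(=O)Nc1ccc(S(F)(F)(F)(F)F)cc1` differs from compound 3 in one place, on an aromatic carbon, where a cyano group takes the place of a larger group: a group of 2 heavy atoms (1 carbon, 1 nitrogen; no ring) in place of a group of 6 heavy atoms (5 fluorine, 1 sulfur; no ring), on an aromatic carbon. For the measured compounds named here, no two measured compounds differ in one place alone, so no measured step shows what such a change does. Starting from compound 3 at 24900 nM, no shift beyond the scatter is expected in this assay. The expected step is a 1.1-fold higher number from compound 3 to compound 4 (0.05 log units; within the scatter). For compound 4 the estimated value is 28000 nM, with an expected range of 12000 nM to 65000 nM.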

Compound 4, half-maximal inhibitory concentration: 32200 nM
Estimate against measurement, compound 4: 1.2-fold (0.06 log units) below; measured number inside the range.
By their numbers in this assay, from the lowest: compounds 3, 2, 4 and 1 (each within the scatter of the next).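

In this assay, a cyano group in place of the group of 6 heavy atoms (5 fluorine, 1 sulfur), on this aromatic carbon para to a large group, gives a 1.3-fold higher number from compound 3 to compound 4 (0.11 log units; within the scatter). For the compounds shown here, this is the first comparison in the set that changes one place alone, and it shows that this assay does not separate these two groups here, despite their difference in size. Nothing measured here bears on why the two groups read alike.

On these data alone, whether an amine or a carboxylic acid on this carbon would move the number beyond the scatter remains open. So does whether the same swap elsewhere in the molecule would read alike.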